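The source may report more compounds than this note shows. Statements on the series, on what has been measured and on what is new or still open speak of the compounds shown alone.

Among the measured compounds shown here, in a functional assay on HL-60 cells (Homo sapiens) for cytotoxicity, read by MTT assay, with a stated time of 24 h (a higher number here means a weaker inhibitor, a lower number a stronger inhibitor), compound 1 `COC(=O)/C(=C\c1ccc(O)cc1)Sc1ccnc2cc(Cl)ccc12` gives 4310 nM and stands lowest of the three numbers measured so far. Compound 2 `COC(=O)/C(=C\c1ccc(OC(=O)c2ccccc2)cc1)Sc1ccnc2cc(Cl)ccc12` reads 30200 nM while compound 3 `COC(=O)/C(=C\c1ccc(OC(=O)c2cccc(OC)c2)cc1)Sc1ccnc2cc(Cl)ccc12` reads 25500 nM in the same measurement. Compound 4 `COC(=O)/C(=C\c1ccc(OC(=O)c2ccccc2OC)cc1)Sc1ccnc2cc(Cl)ccc12` has yet to be measured. It differs from compound 1 by (2-methoxyphenyl)carbonyl in place of hydrogen on an oxygen on an aromatic ring in the form of (2-methoxyphenyl)carbonyl in place of hydrogen on an oxygen on an aromatic ring. Two measured steps make the same kind of change: a 7.0-fold higher number from compound 1 to compound 2 (0.85 log units; beyond the scatter) with benzoyl and a 5.9-fold higher number from compound 1 to compound 3 (0.77 log units; beyond the scatter) with (3-methoxyphenyl)carbonyl are both modest. Adding methoxy to the benzoyl gives a 1.2-fold lower number from compound 2 to compound 3 (0.07 log units; within the scatter) and stays within the scatter. For the measured compounds named here, no measured compound tests the methoxy as it stands in compound 4. A modest step to a higher number is therefore expected in this assay and the estimated step is a 6.0-fold higher number from compound 1 to compound 4 (0.78 log units; beyond the scatter) for this change. For compound 4 the expected value is 26000 nM with an estimated range from 12000 nM to 55000 nM in this measurement.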

Compound 4, half-maximal inhibitory concentration: 44500 nM
Beside the measured number, compound 4's estimate is 1.7-fold (0.23 log units) below it; low and high end bracket the measured number.
By their numbers in this assay, from the lowest: compound 1; then compounds 3, 2 and 4 (each within the scatter of the next).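

In this assay, among the compounds shown here, (2-methoxyphenyl)carbonyl on this oxygen gives a 10-fold higher number from compound 1 to compound 4 (1.01 log units; beyond the scatter) and is the first change here at this position to reach a large step, so all three groups placed on the oxygen now move the number the same way from the hydroxy of compound 1. The methoxy does not separate the esters: 2-methoxyphenyl in place of 3-methoxyphenyl gives a 1.7-fold higher number from compound 3 to compound 4 (0.24 log units; within the scatter) and methoxy in place of hydrogen gives a 1.5-fold higher number from compound 2 to compound 4 (0.17 log units; within the scatter) in this same assay. No evidence is available that bears on the cause of these steps. The compounds shown leave open how an acetyl or a methyl on this oxygen would compare with the free hydroxy. They also leave open how an amine or a carboxylic acid on the benzoyl ring would read.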